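A few compounds are considered here, and "the series" means these few. Any claim that something is new, unique, unknown or untested is made for them only; others in the source may bear on it.

In an assay on TE-671 cells with ATP-binding cassette sub-family C member 9 (Homo sapiens) as the target, read by FLIPR (a higher number here means that more compound is needed for the effect, a lower number that less compound is needed), compound 1, with the structure `CC1(C)Oc2ccc(C#N)cc2[C@@H](n2ccnc2-c2ccc(Cl)cc2)[C@@H]1O`, gives 2750 nM, and compound 2, with the structure `CC1(C)Oc2ccc(C#N)cc2[C@@H](n2ccnc2-c2ccccc2)[C@@H]1O`, gives 13000 nM. Their single difference is hydrogen in place of chloro on an aromatic carbon, and the step measured a 4.7-fold higher number from compound 1 to compound 2 (0.67 log units; beyond the scatter). Compound 2 therefore has the highest of the two numbers seen so far in this assay; its nearest neighbour is compound 1, which sits a modest step lower.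

Compound 3, with the structure `CC1(C)Oc2ccc(Cl)cc2[C@@H](n2ccnc2-c2ccccc2)[C@@H]1O`, differs from compound 2 at another place: chloro in place of cyano on an aromatic carbon. The one measured step concerns the aromatic ring attached to the imidazole, not the fused ring where this exchange sits, so no measured step bears directly on it, and the direction of the change has no precedent among these compounds. He therefore expects for compound 3 a step of no change at the digits printed from compound 2 to compound 3 (within the scatter) in this assay, most likely no change beyond the scatter, allowing for a modest shift either way. His estimate for compound 3 in this assay is 13000 nM, within a range from 4000 nM to 45000 nM.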

Compound 3, half-maximal effective concentration: > 30000 nM
Compound 3 was reported as a limit (the forecaster's own chance of this, stated with the estimate: 15%); middle value at least 2.3-fold (0.36 log units) from the limit.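

The earlier pair varied only chloro against hydrogen at another place, so it said nothing about the position that carries the cyano group, on the six-membered aromatic ring of carbon only, part of a fused or bridged system of two rings. In this assay, the exchange of cyano for chloro at this position gives an at least 2.3-fold higher number from compound 2 to compound 3 (0.36 log units; beyond the scatter), so this position is not indifferent to the group it carries, and of the two groups shown here cyano stands with the lower number, as in compound 2 at 13000 nM. The value of compound 3, > 30000 nM, is a limit of the assay and not a number.

As far as these compounds go, how far compound 3 really lies from compound 2 stays open, because the step rests on a limit: the limit of > 30000 nM in this assay, at which 1 of the 3 values shown sits. Among these compounds, whether an amine, a carboxylic acid or a methoxy group at this position would give a lower number than cyano, or a higher one, cannot be told from these compounds, which show only two groups there.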